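A few compounds are considered here, and "the series" means these few. Any claim that something is new, unique, unknown or untested is made for them only; others in the source may bear on it.

Measured so far in a functional assay on B16-F10 cells (Mus musculus) for antiproliferative activity, read by ELISA and MTT assay, with a stated time of 48 h; on this read-out higher numbers stand for weaker inhibition and lower numbers for stronger inhibition:
compound 1 `O=C(/C=C/c1ccccc1)NS(=O)(=O)c1ccccc1` gives 3.5 ug/mL;
compound 2 `Cc1ccc(S(=O)(=O)NC(=O)/C=C/c2ccccc2)cc1` gives 13.8 ug/mL;
compound 3 `COc1ccc(/C=C/C(=O)NS(=O)(=O)c2ccccc2)cc1` gives 13.2 ug/mL.

Compound 2 differs from compound 1 by methyl in place of hydrogen on an aromatic carbon, and that change gave a 3.9-fold higher number from compound 1 to compound 2 (0.60 log units; beyond the scatter). Compound 3 differs from compound 1 by methoxy in place of hydrogen on an aromatic carbon, with a 3.8-fold higher number from compound 1 to compound 3 (0.58 log units; beyond the scatter). Compound 2 and compound 3 sit within the scatter of each other.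

Compound 4 `COc1ccc(/C=C/C(=O)NS(=O)(=O)c2ccc(C)cc2)cc1` is not yet measured. It differs from compound 3 by methyl in place of hydrogen on an aromatic carbon. For the measured compounds named here, this is the same change as the one from compound 1 to compound 2, made here on the core of compound 3 instead of the core of compound 1.

Compound 4 is expected to give 35 ug/mL in this assay, a step of a 2.7-fold higher number from compound 3 to compound 4 (0.42 log units; beyond the scatter), estimated to fall between 15 ug/mL and 90 ug/mL, because the same change gave a 3.9-fold higher number from compound 1 to compound 2 (0.60 log units; beyond the scatter) and nothing here shows whether it repeats in full on the core of compound 3.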

Compound 4, half-maximal inhibitory concentration: 12.2 ug/mL
Compound 4: the middle estimate sits 2.9-fold (0.46 log units) above what was measured; measured number below the stated range.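

In this assay, methyl in place of hydrogen on an aromatic carbon gave a 1.1-fold lower number from compound 3 to compound 4 (0.03 log units; within the scatter), so the step seen on the core of compound 1 did not carry over to the core of compound 3: the same change on two cores in this assay, a 3.9-fold higher number (0.60 log units; beyond the scatter) from compound 1 to compound 2 and a 1.1-fold lower number (0.03 log units; within the scatter) from compound 3 to compound 4, 4.3-fold (0.63 log units) apart, beyond the scatter of two such steps Methoxy in place of hydrogen behaved the same way, giving a 1.1-fold lower number from compound 2 to compound 4 (0.05 log units; within the scatter), which also failed to repeat its earlier step: the same change on two cores in this assay, a 3.8-fold higher number (0.58 log units; beyond the scatter) from compound 1 to compound 3 and a 1.1-fold lower number (0.05 log units; within the scatter) from compound 2 to compound 4, 4.3-fold (0.63 log units) apart, beyond the scatter of two such steps Neither change can be carried from one core to the other here, but these four compounds do not show why, or whether this holds beyond them.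

The compounds shown leave open how a chlorine atom, a hydroxyl or a longer alkyl chain in place of the methyl would behave on either core. They also leave open what replacing the amide hydrogen would do.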